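From cyclohexylmethoxy to 2-ethylbutoxy on the shared core

The source may report more compounds than this note shows. Statements on the series, on what has been measured and on what is new or still open speak of the compounds shown alone.

Of the compounds shown here, two have been measured in a functional assay on NUGC-3 cells (Homo sapiens) for antiproliferative activity, read by sulforhodamine B assay; a lower number here means a stronger inhibitor of growth, a higher number a weaker inhibitor of growth. In that assay compound 1 `CC(C)(C)CCOc1cccc(O)c1C(=O)/C=C/c1ccc(C(=O)O)cc1` gives 5440 nM. Compound 2 `O=C(/C=C/c1ccc(O)cc1)c1c(O)cccc1OCC1CCCCC1` gives only a limit of the assay, > 30000 nM, and this is the limit of > 30000 nM in this assay, at which 1 of the 2 values shown sits.

Compound 3 `CCC(CC)COc1cccc(O)c1C(=O)/C=C/c1ccc(O)cc1` differs from compound 2 in one place: pentan-3-yl stands in place of cyclohexyl on a saturated chain carbon bound to an oxygen on an aromatic ring (pentan-3-yl in place of cyclohexyl on a saturated chain carbon bound to an oxygen on an aromatic ring). Read one bond further out, cyclohexylmethoxy becomes 2-ethylbutoxy.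

Going by the values given here, no measured pair shows the size of this change. In this assay only a small move towards stronger growth inhibition is expected, and another limit is quite possible. The expected step is an at least 1.2-fold lower number from compound 2 to compound 3 (0.07 log units; that floor lies within the scatter). For compound 3 the estimated value is 25000 nM, with an expected range from 10000 nM to 45000 nM.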

Compound 3, concentration for 50% growth inhibition: 1960 nM
For compound 3 the middle estimate is 13-fold (1.11 log units) above the measured one, outside the stated range (below it).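

In this assay, compound 3 gives a real number where compound 2 gives only a limit of the assay, so the group on the saturated chain carbon bound to an oxygen on an aromatic ring clearly matters for growth inhibition. The change is an at least 15-fold lower number from compound 2 to compound 3 (1.18 log units; beyond the scatter), although it swaps one all-carbon group for another and neither group carries a hydrogen-bond donor or acceptor. That step gives only a floor and not a full size, because compound 2 stands at a limit: the limit of > 30000 nM in this assay, at which 1 of the 3 values shown sits.

This single pair cannot separate the loss of the ring from the branching of the open chain. On these data alone, how an unbranched pentyl chain, a cyclopentylmethyl group or a chain ending in an amine would read on the same core remains open.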